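Swapping the ring-nitrogen substituent for methylsulfonyl

The source may report more compounds than this note shows. Statements on the series, on what has been measured and on what is new or still open speak of the compounds shown alone.

Compound 2 `Cc1nc(N2CCN(C3CCOCC3)CC2)nc2ccc(NC(=O)COc3ccc(Cl)cc3)cc12` gives 45 nM in an assay on CHO-K1 cells for displacement of a labelled ligand from melanin-concentrating hormone receptor 1 (Homo sapiens), with a stated time of 2 h (on this read-out higher numbers stand for weaker inhibition and lower numbers for stronger inhibition), the lower of the two numbers measured; compound 1 `Cc1nc(N2CCN(C3CCCC3)CC2)nc2ccc(NC(=O)COc3ccc(Cl)cc3)cc12` gives 96 nM. For the measured compounds named here, the one step seen at this position, a 2.1-fold lower number from compound 1 to compound 2 (0.33 log units; beyond the scatter), was modest. Compound 3 `Cc1nc(N2CCN(S(C)(=O)=O)CC2)nc2ccc(NC(=O)COc3ccc(Cl)cc3)cc12` changes the same spot differently: methylsulfonyl in place of oxan-4-yl on an amine nitrogen in a ring. Because that step a 2.1-fold lower number from compound 1 to compound 2 (0.33 log units; beyond the scatter) compared two ring groups and nothing here tests a methylsulfonyl, the direction is uncertain; a small-to-moderate rise in the number is expected, roughly a 3.3-fold higher number from compound 2 to compound 3 (0.52 log units; beyond the scatter). Compound 3 is therefore estimated at 150 nM, within 40 nM to 600 nM.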

Compound 3, half-maximal inhibitory concentration: > 10000 nM
Compound 3: a limit, no number; the forecaster's own chance of this, stated with the estimate: 5%; middle value at least 66-fold (1.82 log units) away from the limit.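

At this position, the choice between the two ring groups matters far less than the change to methylsulfonyl. The step between those ring groups is only a 2.1-fold lower number from compound 1 to compound 2 (0.33 log units; beyond the scatter), whereas methylsulfonyl gives an at least 220-fold higher number from compound 2 to compound 3 (2.34 log units; beyond the scatter) and an at least 100-fold higher number from compound 1 to compound 3 (2.01 log units; beyond the scatter). Compound 3 gives a limit of the assay, not a number: the limit of > 10000 nM in this assay, at which 1 of the 3 values shown sits.

Methylsulfonyl both adds a sulfonyl and removes the ring, and these compounds cannot separate the two changes. Acetyl, which has no ring or sulfur, and cyclopentylsulfonyl, which keeps a ring alongside the sulfonyl, would each test one side of that question.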